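A few compounds are considered here, and "the series" means these few. Any claim that something is new, unique, unknown or untested is made for them only; others in the source may bear on it.

Three compounds sharing one heterocyclic scaffold were tested in an ADME assay on BEAS-2B cells (Homo sapiens) for cytotoxicity, read by MTT assay, with a stated time of 72 h; on this read-out lower numbers stand for stronger inhibition of growth and higher numbers for weaker inhibition of growth. Compound 1 `CSc1nc(NCCCCCO)c2cccnc2n1` reaches only > 100000 nM, which is a limit of the assay and not a number (the limit of > 100000 nM in this assay, at which 1 of the 3 values shown sits). Compound 2 `CSc1nc(NCc2ccccc2)c2ccccc2n1` gives 38900 nM in this assay. Compound 3 `CSc1nc(NCc2ccccc2)c2cccnc2n1` gives 25900 nM in this assay, and the values of compound 2 and compound 3 lie within the usual scatter of each other. How the cores of compound 2 and compound 3 differ is not broken down here. Compound 3 and compound 1 differ in one place 4-hydroxybutyl in place of phenyl on a saturated chain carbon bound to a nitrogen on an aromatic ring and that change brought an at least 3.8-fold higher number from compound 3 to compound 1 (0.58 log units; beyond the scatter). Compound 4 `CSc1nc(NCCCCCO)c2ccccc2n1`, still unmeasured, differs from compound 2 by the same change at the same place (4-hydroxybutyl in place of phenyl on a saturated chain carbon bound to a nitrogen on an aromatic ring). A comparable weakening is expected, so the step of a 3.9-fold higher number from compound 2 to compound 4 (0.59 log units; beyond the scatter) is estimated to resemble the measured one an at least 3.8-fold higher number from compound 3 to compound 1 (0.58 log units; beyond the scatter), since compound 2 already sits at 38900 nM. Compound 4 is therefore estimated at about 150000 nM in this assay, likely between 60000 nM and 400000 nM, with a real chance that only a limit is reported.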

Compound 4, concentration for 50% growth inhibition: 39300 nM
Beside the measured number, compound 4's estimate is 3.8-fold (0.58 log units) above it, and the stated range ends above it.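

In this assay, 4-hydroxybutyl in place of phenyl gave a 1.0-fold higher number from compound 2 to compound 4 (0.00 log units; within the scatter), so on this core the change left no mark on the read-out, and the step seen on the core of compound 3 did not carry over: the same change on two cores in this assay, an at least 3.8-fold higher number (0.58 log units; beyond the scatter) from compound 3 to compound 1 and a 1.0-fold higher number (0.00 log units; within the scatter) from compound 2 to compound 4, at least 3.8-fold (0.58 log units) apart, beyond the scatter of two such steps. On these data alone, compound 1 gives > 100000 nM, which is a limit of the assay and not a number, so the size of the step on that core stays open-ended. The two steps show that, for this pair of cores, the result of the change depends on the core it is made on, but they do not show why, and one pair of cores gives no rule for any other core in the series.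

As far as these compounds go, it remains open whether an amine or a carboxylic acid at the end of the chain, in place of the hydroxyl, would follow compound 1 or compound 4. The same holds for a longer chain, on either core.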